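This account rests on a few compounds, and the source may have more. Where it says the series, first, only, none or still open, it means among the compounds named here.

In a functional assay on DU-145 cells (Homo sapiens) for cytotoxicity, read by trypan blue exclusion, with a stated time of 96 h (on this read-out lower numbers stand for stronger inhibition and higher numbers for weaker inhibition), compound 1 `COc1cc(OC)c(/C=C/S(=O)(=O)Cc2ccc(OC)c(N)c2)c(OC)c1` gives 4 nM while compound 2 `COC(=O)C(Nc1cc(CS(=O)(=O)/C=C/c2c(OC)cc(OC)cc2OC)ccc1OC)c1ccccc1` gives 75 nM and so holds the higher of the two numbers. Compound 3 `COc1cc(OC)c(/C=C/S(=O)(=O)Cc2ccc(OC)c(NCCC(=O)O)c2)c(OC)c1` alters the same nitrogen and 2-carboxyethyl in place of methoxycarbonyl)(benzyl on a nitrogen on an aromatic ring is the change, with 2-carboxyethyl in place of methoxycarbonyl)(benzyl. Going by the values given here, the one measured step bearing on this is a 19-fold higher number from compound 1 to compound 2 (1.27 log units; beyond the scatter) at that nitrogen. The expected step is estimated as a 2.5-fold lower number from compound 2 to compound 3 (0.40 log units; beyond the scatter) in this assay and runs towards a lower number, recovering only part of the earlier one. For compound 3 the estimated value is 30 nM with an expected range from 8 nM to 120 nM as its upper end.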

Compound 3, half-maximal inhibitory concentration: 5000 nM
Beside the measured number, compound 3's estimate is 170-fold (2.22 log units) below it; the whole stated range lies below it.
By their numbers in this assay, from the lowest: compound 1; then compound 2; then compound 3.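

Replacing methoxycarbonyl)(benzyl with 2-carboxyethyl on this nitrogen gives a 67-fold higher number from compound 2 to compound 3 (1.82 log units; beyond the scatter), so the outcome at this position depends strongly on the group that enters, and the group with fewer heavy atoms is the worse one here. Measured against the free amine, the loss is a 1300-fold higher number from compound 1 to compound 3 (3.10 log units; beyond the scatter), far larger than a 19-fold higher number from compound 1 to compound 2 (1.27 log units; beyond the scatter), the other substitution at this nitrogen. Nothing available accounts for the gap between the two groups. Open, from the compounds shown here alone, is whether the carboxylic acid or the chain carries the loss. A methyl ester or primary amide on the same chain would separate the two, as would a plain alkyl chain.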